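The source may report more compounds than this note shows. Statements on the series, on what has been measured and on what is new or still open speak of the compounds shown alone.

In a functional assay on PC-3 cells (Homo sapiens) for antiproliferative activity, read by MTT assay, with a stated time of 72 h (on this read-out higher numbers stand for weaker inhibition and lower numbers for stronger inhibition), compound 1 (`C#CCSc1nc(Sc2ccccn2)c(C#N)c(-c2cc(OC)c(OC)c(OC)c2)n1`) gives > 10000 nM as a limit and not as a number. Within the data shown here, compound 2 (`C#CCSc1nc(Sc2nc3ccccc3s2)c(C#N)c(-c2cc(OC)c(OC)c(OC)c2)n1`) gives > 20000 nM as a limit too, so it has no readable position, and the only other value is also a limit. Compound 3 (`C#CCSc1nc(Sc2nc(C)cs2)c(C#N)c(-c2cc(OC)c(OC)c(OC)c2)n1`) carries 4-methyl-1,3-thiazol-2-yl in place of 1,3-benzothiazol-2-yl on a sulfur. Among the measured compounds shown here, the one measured step at a group on that sulfur (a step that the two limits leave unreadable from compound 1 to compound 2) offers no size and no direction to carry over. On that basis, no step beyond the scatter is expected in this assay for this change. The expected step (a number no higher from compound 2 to compound 3 (the limit leaves the size open)) is therefore only a placeholder estimate. For compound 3 the estimated value is 20000 nM with an expected range from 5000 nM to 40000 nM and a report as a limit is the likelier outcome.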

Compound 3, half-maximal inhibitory concentration: > 20000 nM
Compound 3 gave a limit, no number (the forecaster's own chance of this, stated with the estimate: 75%); the middle value sits exactly at the limit.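

In this assay compound 3 is reported only as a limit, like compound 1 and compound 2, so no step among these three compounds can be read: the limit of > 20000 nM in this assay, at which 2 of the 3 values shown sit.

The compounds shown leave open whether any group on that sulfur gives a readable number in this assay.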